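This account rests on a few compounds, and the source may have more. Where it says the series, first, only, none or still open, it means among the compounds named here.

Measured so far:
compound 1, `CCCCCCCC/C=C\CCCCCCC(=O)c1ncc(-c2ccco2)o1`: 54 nM
compound 2, `CCCCCCCCCCCCCCCCCC(=O)C(F)(F)F`: 240 nM

Two compounds have numbers in an assay on isolated protein for inhibition of Fatty-acid amide hydrolase 1 (Homo sapiens); a higher number here means a weaker inhibitor, a lower number a stronger inhibitor. Compound 1, a long-chain ketone with an unsaturated chain attached to a heteroaromatic core, gives 54 nM. Compound 2, a saturated straight-chain trifluoromethyl ketone, gives 240 nM; it stands at the higher of the two numbers, and its gap to compound 1 lies beyond the usual scatter of this assay. Going by the values given here, no pair among the measured compounds differs in a single place, so no step is available to lean on.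

Compound 3, `CCCCCCCCCCCCCC(=O)C(F)(F)F`, is the next compound to be measured in this assay. It differs from compound 2 as follows: hydrogen in place of butyl on a saturated chain carbon, ten or more bonds along the chain from a carbonyl carbon. The chain is thus shortened at its far end while the trifluoromethyl ketone is kept.

With no measured step of this kind in the series, the expectation rests on compound 2 alone. A shorter saturated chain is expected to give a somewhat weaker inhibitor, a step of a 2.1-fold higher number from compound 2 to compound 3 (0.32 log units; beyond the scatter) from compound 2, of a size that may or may not stand out from the scatter. For compound 3 the estimated inhibition constant is 500 nM, with a range from 150 nM to 1800 nM.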

Compound 3, inhibition constant: 490 nM
Estimate against measurement, compound 3: 1.0-fold (0.01 log units) above; the measured number falls inside the stated range.
By their numbers in this assay, from the lowest: compound 1; then compound 2; then compound 3.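

In this assay the trifluoromethyl ketones now have their first step that differs in one place. Replacing butyl with hydrogen on a saturated chain carbon gives a 2.0-fold higher number from compound 2 to compound 3 (0.31 log units; beyond the scatter) as a modest change that still registers, so the far end of the chain is not silent, though inhibition does not rest wholly on the butyl. No measurement among the data accounts for this step.

A single step on one chain cannot show whether the number keeps rising with a shorter chain, or whether a longer chain would lower it further, and it leaves open how an unsaturated chain of the kind in compound 1 would behave on the trifluoromethyl ketone. Compound 1 differs from compound 2 in more than one place, so its lower number cannot be assigned to the chain or to the core of compound 1, and the effect of a carboxylic acid or an amine at the far end of the chain also remains unanswered.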